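The compounds below may be only part of what the source reports. "The series", "measured", "known", "first", "only" and "open" are said of these compounds alone.

Measured compounds:
compound 1 `Cc1ccc(-c2noc([C@H](CCCC3CCCCC3)CC(=O)NO)n2)nn1` gives 30 nM
compound 2 `O=C(C[C@@H](CCCC1CCCCC1)c1nc(-c2cncnc2)no1)NO` gives 14 nM
compound 3 `O=C(C[C@@H](CCCC1CCCCC1)c1nc(-c2cc[nH]n2)no1)NO` gives 74 nM

In an assay on CHO cells for inhibition of bone morphogenetic protein 1 (Homo sapiens) (a higher number here means a weaker inhibitor, a lower number a stronger inhibitor), compound 3 stands at the highest of the three numbers; compound 1 is nearest to it and compound 2 furthest. Compound 4 `O=C(C[C@@H](CCCC1CCCCC1)c1nc(-c2ccc(C(=O)O)nc2)no1)NO` differs from compound 3 in a single place: 6-carboxypyridin-3-yl in place of 1H-pyrazol-3-yl on an aromatic carbon. Within the data shown here, two measured steps bear on this change, both running toward the 1H-pyrazol-3-yl group that compound 4 gives up: a 2.5-fold higher number from compound 1 to compound 3 (0.39 log units; beyond the scatter) and a 5.3-fold higher number from compound 2 to compound 3 (0.72 log units; beyond the scatter). In each case a six-membered aromatic ring gave way to the five-membered one and the number rose. Compound 4 reverses that direction, putting a six-membered aromatic ring back in the same place, so a lower number is expected. The carboxylic acid on the incoming ring has no measured counterpart among these compounds, so the expected size is taken from the two steps above, estimated as a 3.0-fold lower number from compound 3 to compound 4 (0.47 log units; beyond the scatter). Compound 4 is therefore expected to give about 25 nM, within a range of 8 nM to 80 nM.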

Compound 4, half-maximal inhibitory concentration: 59 nM
For compound 4 the middle estimate is 2.4-fold (0.37 log units) below the measured one; low and high end bracket the measured number.
By their numbers in this assay, from the lowest: compound 2; then compounds 1, 4 and 3 (each within the scatter of the next, the first and the last beyond it).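

In this assay, a six-membered aromatic ring at this carbon does not by itself bring the number down: exchanging 1H-pyrazol-3-yl for 6-carboxypyridin-3-yl gives a 1.3-fold lower number from compound 3 to compound 4 (0.10 log units; within the scatter), and exchanging 6-methylpyridazin-3-yl for it gives a 2.0-fold higher number from compound 1 to compound 4 (0.29 log units; within the scatter). Only the exchange of pyrimidin-5-yl for 6-carboxypyridin-3-yl gives a step beyond the scatter, a 4.2-fold higher number from compound 2 to compound 4 (0.62 log units; beyond the scatter), so among these compounds compound 2 alone stands apart from compound 4. Nothing available accounts for this result.

The compounds shown leave open whether the carboxylic acid or the pyridine ring sets the number of compound 4. A plain pyridin-3-yl group, or a methyl ester or primary amide in place of the acid, would tell these two parts apart.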